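The source may hold more compounds than are shown below. What is called first, only, known or untested is meant among the compounds shown, and "the series" means these compounds.

Three compounds have been measured in a functional assay on HO8910 cells (Homo sapiens) for cytotoxicity, read by CCK-8 assay, with a stated time of 24 h; a higher number here means a weaker inhibitor, a lower number a stronger inhibitor:

Compound 1 `C/C(=C\c1cc(-c2ccc(C)cc2)co1)C(N)=O` gives 24200 nM.
Compound 2 `C/C(=C\c1cc(-c2ccc(F)cc2)co1)C(N)=O` gives only a limit of the assay, > 50000 nM.
Compound 3 `C/C(=C\c1ccc(-c2ccc(C)cc2)o1)C(N)=O` gives 1660 nM.

The step from compound 1 to compound 2 is fluoro in place of methyl on an aromatic carbon, and the measured change was an at least 2.0-fold higher number from compound 1 to compound 2 (0.31 log units; beyond the scatter); its size is known only as a bound because of the limit of > 50000 nM in this assay, at which 1 of the 3 values shown sits. Compound 3 and compound 1 are built from the same atoms joined differently; the difference between the two cores is not broken down here, and compound 3 gives the lower number.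

Compound 4 `C/C(=C\c1ccc(-c2ccc(F)cc2)o1)C(N)=O` is not yet measured. It differs from compound 3 by fluoro in place of methyl on an aromatic carbon, the same change that was seen between compound 1 and compound 2. Judged by that earlier step, an at least 2.0-fold higher number from compound 1 to compound 2 (0.31 log units; beyond the scatter), a weakening of about a 3.6-fold higher number from compound 3 to compound 4 (0.56 log units; beyond the scatter) is expected from compound 3 to compound 4. Compound 4 is therefore estimated at 6000 nM, most likely between 2500 nM and 25000 nM.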

Compound 4, half-maximal inhibitory concentration: 990 nM
Estimate against measurement, compound 4: 6.1-fold (0.78 log units) above; the measured number lies below the stated range.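

In this assay, putting fluoro in place of methyl on an aromatic carbon gives a 1.7-fold lower number from compound 3 to compound 4 (0.22 log units; within the scatter), so on this core the two compounds stay within the scatter of each other. The change therefore does not carry over from one core to the other with the same result: the same change on two cores in this assay, an at least 2.0-fold higher number (0.31 log units; beyond the scatter) from compound 1 to compound 2 and a 1.7-fold lower number (0.22 log units; within the scatter) from compound 3 to compound 4, at least 3.4-fold (0.53 log units) apart, beyond the scatter of two such steps. Going by these compounds, compound 2 stands at a limit of the assay, > 50000 nM, so the true size of the earlier step remains unknown, and two cores cannot establish a rule for the series.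

The compounds shown leave open how chloro, methoxy or an amine at the same place would behave on either core. They also leave open why the two cores respond differently to this change.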